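The source may report more compounds than this note shows. Statements on the series, on what has been measured and on what is new or still open speak of the compounds shown alone.

Measured so far in a functional assay on cells (Tumor Cell line, Homo sapiens) for cytotoxicity; a higher number here means a weaker inhibitor of growth, a lower number a stronger inhibitor of growth:
compound 1 `COc1ccccc1-c1cc(O)c2cc(C)cnc2n1` 31600 nM
compound 2 `Cc1cc(C)c2c(O)cc(-c3ccc(Cl)cc3)nc2n1` 19500 nM
compound 3 `COc1ccc(-c2cc(O)c3c(C)cc(C)nc3n2)cc1` 33100 nM

Compound 3 sits among the three with compound 1 at 31600 nM and compound 2 at 19500 nM both within the scatter of it, so the three numbers are not separable. Going by the values given here, the one single-point step, a 1.7-fold higher number from compound 2 to compound 3 (0.23 log units; within the scatter), concerns the methoxy against chloro and lies within the scatter.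

Compound 4 `COc1ccc(-c2cc(O)c3ccc(C)nc3n2)cc1` differs from compound 3 in one place: hydrogen in place of methyl on an aromatic carbon. Among the compounds with values here, no measured pair tells of removing a methyl from the shared core, so nothing bears directly on this step. With the whole series flat in this assay, the expected step is a 1.0-fold lower number from compound 3 to compound 4 (0.00 log units; within the scatter), meaning none beyond the scatter. Compound 4 is therefore estimated at 33000 nM, within 15000 nM to 75000 nM.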

Compound 4, concentration for 50% growth inhibition: 91200 nM
For compound 4 the middle estimate is 2.8-fold (0.44 log units) below the measured one, outside the stated range (above it).
By their numbers in this assay, from the lowest: compounds 2, 1 and 3 (each within the scatter of the next); then compound 4.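

In this assay, going by these compounds alone, hydrogen in place of methyl on this aromatic carbon, opposite the ring nitrogen, gives a 2.8-fold higher number from compound 3 to compound 4 (0.44 log units; beyond the scatter), the only step so far beyond the scatter. This position on the shared core therefore registers in the read-out, whereas the methoxy against chloro step did not, though the finding rests on a single pair. No measurement at hand accounts for the step. Open, as far as these compounds go, is whether an ethyl or an amine on this carbon would keep the stronger growth inhibition of the methyl. Also open, from the compounds shown here alone, is whether the step holds with chloro in place of methoxy.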